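Nitro for hydroxy: a second pass on a varied core

This account rests on a few compounds, and the source may have more. Where it says the series, first, only, none or still open, it means among the compounds named here.

Compound 1 `COc1ccc(C2=Cc3ccc(F)cc3C(CC(C)=O)N2c2ccc(O)cc2)cc1`, compound 2 `COc1ccc(C2=Cc3ccc(F)cc3C(CC(C)=O)N2c2ccc([N+](=O)[O-])cc2)cc1` and compound 3 `COc1ccc(C2=Cc3ccc(F)cc3C(CC(=O)C(C)O)N2c2ccc(O)cc2)cc1` have been run; compound 4 `COc1ccc(C2=Cc3ccc(F)cc3C(CC(=O)C(C)O)N2c2ccc([N+](=O)[O-])cc2)cc1` has not. In an ADME assay on TZM cells (Homo sapiens) for cytotoxicity, read by CellTiter-Glo, with a stated time of 48 h (on this read-out lower numbers stand for higher toxicity in this test and higher numbers for lower toxicity in this test), compound 1 gives 60500 nM, compound 2 gives 11200 nM and compound 3 gives 50900 nM. The change nitro in place of hydroxy on an aromatic carbon brought a 5.4-fold lower number from compound 1 to compound 2 (0.73 log units; beyond the scatter). The core of compound 3 differs from that of compound 1 by 1-hydroxyethyl in place of methyl on a carbonyl carbon, which brought a 1.2-fold lower number from compound 1 to compound 3 (0.08 log units; within the scatter), so the two cores sit close in this assay. Compound 4 carries the change nitro in place of hydroxy on an aromatic carbon on the core of compound 3; the place of that change reads the same, word for word, as in the pair of compound 1 and compound 2, so it is the same change made twice in the set. The expectation for compound 4 rests on that single measured pair alone. The step from compound 3 to compound 4 is expected to be a 5.4-fold lower number from compound 3 to compound 4 (0.73 log units; beyond the scatter), close to the earlier one, because a 5.4-fold lower number from compound 1 to compound 2 (0.73 log units; beyond the scatter) was observed on a core that compound 3 matches within the scatter. In this assay compound 4 is therefore estimated at 9500 nM, with a likely range from 4500 nM to 20000 nM.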

Compound 4, half-maximal cytotoxic concentration: 10100 nM
Beside the measured number, compound 4's estimate is 1.1-fold (0.03 log units) below it, and the stated range covers the measured number.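

In this assay, nitro in place of hydroxy on an aromatic carbon brought a 5.0-fold lower number from compound 3 to compound 4 (0.70 log units; beyond the scatter), so the change carried over from one core to the other with its size intact: the same change on two cores in this assay, a 5.4-fold lower number (0.73 log units; beyond the scatter) from compound 1 to compound 2 and a 5.0-fold lower number (0.70 log units; beyond the scatter) from compound 3 to compound 4, 1.1-fold (0.03 log units) apart, within the scatter of two such steps. Read the other way, 1-hydroxyethyl in place of methyl on a carbonyl carbon brought a 1.1-fold lower number from compound 2 to compound 4 (0.04 log units; within the scatter), and this step too stays the same whichever of the two aromatic groups is present: the same change on two cores in this assay, a 1.2-fold lower number (0.08 log units; within the scatter) from compound 1 to compound 3 and a 1.1-fold lower number (0.04 log units; within the scatter) from compound 2 to compound 4, 1.1-fold (0.03 log units) apart, within the scatter of two such steps. The two changes therefore behave as independent steps across these four compounds, but the two cores lie within the scatter of each other, so this is a narrow test that shows nothing about a core further removed and gives no reason for the lower number with nitro.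

The compounds shown leave open whether an amine or a carboxylic acid in that place on the aromatic ring would bring a step of like size. They also leave open whether a longer chain on the carbonyl carbon would stay as close to methyl as 1-hydroxyethyl does.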